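Shortening the Chain: Lipophilicity from Dodecyl to Decyl

A few compounds are considered here, and "the series" means these few. Any claim that something is new, unique, unknown or untested is made for them only; others in the source may bear on it.

Measured so far in a physicochemical assay for lipophilicity; on this read-out lower numbers stand for lower lipophilicity and higher numbers for higher lipophilicity:
Compound 1 `CCCCCCCCNCCO` gives 2.55.
Compound 2 `CCCCCCCCCCCCNCCO` gives 3.93.

For the measured compounds named here, compound 2 stands highest of the two numbers; its only neighbour is compound 1, and the step of a number 1.38 log units higher from compound 1 to compound 2 (beyond the scatter) separates them clearly. Compound 3 `CCCCCCCCCCNCCO` differs from compound 2 by hydrogen in place of ethyl on a saturated chain carbon, ten or more bonds along the chain from an amine nitrogen. Going by the values given here, the single measured step, a number 1.38 log units higher from compound 1 to compound 2 (beyond the scatter), came with butyl in place of hydrogen; here ethyl leaves instead, so a drop in this assay is expected. Compound 3 is therefore estimated at 3.24, between 2.95 and 3.55, an expected step of a number 0.69 log units lower from compound 2 to compound 3 (beyond the scatter).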

Compound 3, partition coefficient: 3.09
The estimate for compound 3 lay 0.15 log units above the measured number; measured number inside the range.
By their numbers in this assay, from the lowest: compound 1; then compound 3; then compound 2.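

Ethyl now counts on its own in this assay: with hydrogen in place of ethyl there is a number 0.84 log units lower from compound 2 to compound 3 (beyond the scatter), and with ethyl in place of hydrogen on the shorter chain there is a number 0.54 log units higher from compound 1 to compound 3 (beyond the scatter). The number therefore rises in two separate stages as the chain lengthens, and none of the three compounds goes against that order. Nothing available explains the size of either step.

Going by these compounds, whether a longer chain would continue this rise remains open. So does where a compound carrying a carboxylic acid would fall.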